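Hexyl to cyclopentenyl ester exchange on the ring nitrogen

This account rests on a few compounds, and the source may have more. Where it says the series, first, only, none or still open, it means among the compounds named here.

For the measured compounds named here, compound 3 `CCCCCCNc1ncnc2c1nnn2[C@@H]1C[C@@H](COS(N)(=O)=O)[C@@H](O)C1` gives 21.1 nM in an assay on a protein complex for inhibition of NEDD8 activating enzyme (Homo sapiens), read by HTRF, with a stated time of 2 h, in the presence of a further agent that is not named here (on this read-out lower numbers stand for stronger inhibition and higher numbers for weaker inhibition), the highest of the three numbers measured so far. In this assay compound 1 `NS(=O)(=O)OC[C@@H]1C[C@@H](n2nnc3c(N[C@H]4CCc5ccccc54)ncnc32)C[C@@H]1O` gives 0.21 nM and compound 2 `NS(=O)(=O)OC[C@@H]1C[C@@H](n2nnc3c(NCc4ccccc4F)ncnc32)C[C@@H]1O` gives 6.11 nM. The gaps are a 100-fold higher number from compound 1 to compound 3 (2.00 log units; beyond the scatter) and a 3.5-fold higher number from compound 2 to compound 3 (0.54 log units; beyond the scatter), both beyond the scatter. Compound 4 `COC(=O)[C@H]1C=C[C@@H](Nc2ncnc3c2nnn3[C@@H]2C[C@@H](COS(N)(=O)=O)[C@@H](O)C2)C1` differs from compound 3 by a group of 9 heavy atoms (7 carbon, 2 oxygen; one five-membered non-aromatic ring of carbon only) in place of a group of 6 heavy atoms (6 carbon; no ring), on a nitrogen on an aromatic ring. The step that bears most is a 100-fold higher number from compound 1 to compound 3 (2.00 log units; beyond the scatter), in which a group holding a ring directly on that nitrogen went with a much lower number; a 3.5-fold higher number from compound 2 to compound 3 (0.54 log units; beyond the scatter) is modest and points the same way. Both steps favour a lower number for compound 4 in this assay, but the entering group has a single five-membered non-aromatic ring with a methyl ester rather than the 2,3-dihydro-1H-inden-1-yl group of compound 1, so the expected gain is taken as less than the whole span back to compound 1. Compound 4 is therefore expected at 3 nM, with a range of 0.5 nM to 20 nM. The estimated step is a 7.0-fold lower number from compound 3 to compound 4 (0.85 log units; beyond the scatter).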

Compound 4, half-maximal inhibitory concentration: 80.9 nM
Estimate against measurement, compound 4: 27-fold (1.43 log units) below, outside the stated range (above it).
By their numbers in this assay, from the lowest: compound 1; then compound 2; then compound 3; then compound 4.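

In this assay, a ring in the group on the nitrogen on an aromatic ring does not by itself go with a lower number: compound 4 goes against the trend set by compounds 1 and 2, with a 3.8-fold higher number from compound 3 to compound 4 (0.58 log units; beyond the scatter) relative to the hexyl chain, which has no ring. The rise is larger against the 2-fluorobenzyl group, a 13-fold higher number from compound 2 to compound 4 (1.12 log units; beyond the scatter), and larger still against the 2,3-dihydro-1H-inden-1-yl group, a 390-fold higher number from compound 1 to compound 4 (2.59 log units; beyond the scatter), so matching that group's heavy-atom count and five-membered non-aromatic ring does not preserve its low number. No supporting data bear on the origin of this rise.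

The methyl ester, the ring double bond and the two defined stereocentres change together here, so their separate contributions remain unresolved. From the compounds shown here alone, whether a carboxylic acid or a primary amide in place of the methyl ester, or the bare cyclopentyl ring, would lower the number remains open.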